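The source may hold more compounds than are shown below. What is called first, only, known or untested is meant among the compounds shown, and "the series" means these compounds.

Measured compounds in an assay for displacement of a labelled ligand from 5-hydroxytryptamine receptor 4 (Homo sapiens), with a stated time of 60 min; a lower number here means a stronger inhibitor, a higher number a weaker inhibitor:
compound 1, `COc1c(C(=O)CCC2CCN(CC3CCCCC3)CC2)cc(Cl)c2[nH]ccc12`, 40.9 nM;
compound 2, `O=C(CCC1CCN(CC2CCCCC2)CC1)c1cc(Cl)c2[nH]ccc2c1`, 37.5 nM;
compound 3, `O=C(CCC1CCN(Cc2ccccc2)CC1)c1ccc2[nH]ccc2c1`, 169 nM.

Compound 3 gives the highest of the three numbers; compounds 1 and 2 both sit well below it, beyond the scatter. Compound 4, `O=C(CCC1CCN(CC2CCCCC2)CC1)c1ccc2[nH]ccc2c1`, differs from compound 3 by cyclohexyl in place of phenyl on a saturated chain carbon bound to an amine nitrogen in a ring. Within the data shown here, no measured step isolates this change: the only single-point step, a 1.1-fold lower number from compound 1 to compound 2 (0.04 log units; within the scatter), concerns a methoxy and lies within the scatter. Compound 2 carries the cyclohexylmethyl group that compound 4 acquires, but it also carries a chlorine that compound 4 lacks, so its lower number cannot be assigned to either feature alone. Compound 4 is therefore expected to move toward the values of compounds 1 and 2, a step of a 2.6-fold lower number from compound 3 to compound 4 (0.41 log units; beyond the scatter), and its estimate in this assay is 65 nM, within 25 nM to 170 nM.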

Compound 4, inhibition constant: 37.5 nM
The estimate for compound 4 lay 1.7-fold (0.24 log units) above the measured number; the range from low to high includes it.
By their numbers in this assay, from the lowest: compounds 2, 4 and 1 (each within the scatter of the next); then compound 3.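

In this assay, among these compounds, cyclohexyl in place of phenyl on a saturated chain carbon bound to an amine nitrogen in a ring gives a 4.5-fold lower number from compound 3 to compound 4 (0.65 log units; beyond the scatter), so this change alone, isolated for the first time, is enough to shift the number beyond the scatter. Hydrogen in place of chloro gives no change at the digits printed from compound 2 to compound 4 (within the scatter), so the chloro is not needed for this value when cyclohexylmethyl is present. No measurement offered here bears on the reason for these results. Going by these compounds, whether cyclopentyl or cyclohexylethyl would hold this number remains open, as does whether chloro would matter with benzyl in place of cyclohexylmethyl.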